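The source may hold more compounds than are shown below. What is called first, only, known or untested is meant among the compounds shown, and "the series" means these compounds.

Series notes. The three measured compounds share one core and differ only in the group on an amine nitrogen in a ring. Compound 1 `Nc1ccccc1NC(=O)c1ccc(CSC(=S)N2CCN(Cc3ccccn3)CC2)cc1` gives 65.2% in a functional assay on MGC-803 cells (Homo sapiens) for antiproliferative activity, read by CCK-8 assay, with a stated time of 72 h, tested at 8 uM; on this read-out lower numbers stand for a weaker effect and higher numbers for a stronger effect at the one concentration tested. Compound 2 `Nc1ccccc1NC(=O)c1ccc(CSC(=S)N2CCN(c3cccnc3)CC2)cc1` gives 76.9% in this assay, and compound 3 `Nc1ccccc1NC(=O)c1ccc(CSC(=S)N2CCN(c3ccccc3F)CC2)cc1` gives 86.4%. Compound 3 holds the highest of the three numbers; the step of a number 21.2 percentage points higher from compound 1 to compound 3 (beyond the scatter) lies beyond the scatter, while a number 9.5 percentage points higher from compound 2 to compound 3 (within the scatter) lies within it, so compound 3 and compound 2 cannot be ordered against each other.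

Compound 4 `Nc1ccccc1NC(=O)c1ccc(CSC(=S)N2CCN(C3CCCCC3)CC2)cc1` is the next member, with the change (cyclohexyl in place of 2-fluorophenyl on an amine nitrogen in a ring). Within the data shown here, no measured step exchanges an aromatic ring for a non-aromatic one at this position, so none bears directly on it. The steps available, a number 11.7 percentage points higher from compound 1 to compound 2 (beyond the scatter) and a number 21.2 percentage points higher from compound 1 to compound 3 (beyond the scatter), both start from compound 1 and both raise the number by a modest amount. With nothing closer to go on, a modest downward step or none beyond the scatter is expected. Compound 4 is estimated at 72%, with a range from 52% to 88%. The expected step is a number 14.4 percentage points lower from compound 3 to compound 4 (beyond the scatter).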

Compound 4, a percentage reported as inhibition, at one concentration (the size of the read-out at that concentration, not a potency): 75.3%
For compound 4 the middle estimate is 3.3 percentage points below the measured one; the measured number falls inside the stated range.
By their numbers in this assay, from the lowest: compound 1; then compounds 4, 2 and 3 (each within the scatter of the next, the first and the last beyond it).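

Among these compounds, compound 4 puts a non-aromatic ring on this amine nitrogen for the first time, and in this assay the result depends on which aromatic group cyclohexyl replaces: the number falls against 2-fluorophenyl (a number 11.1 percentage points lower from compound 3 to compound 4 (beyond the scatter)) but does not separate from pyridin-3-yl (a number 1.6 percentage points lower from compound 2 to compound 4 (within the scatter)). An aromatic ring here is therefore not required to reach the level of compound 2, though the level of compound 3 is not matched. Cyclohexyl also stands clear of (pyridin-2-yl)methyl (a number 10.1 percentage points higher from compound 1 to compound 4 (beyond the scatter)), so the lowest number of the set no longer simply separates aromatic from non-aromatic groups. No measured property is available to account for these steps.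

A benzyl group would separate the methylene link from the ring nitrogen of (pyridin-2-yl)methyl. As far as these compounds go, whether a ring is needed at all remains open, and an open hexyl chain on this nitrogen would address that.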